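A few compounds are considered here, and "the series" means these few. Any claim that something is new, unique, unknown or untested is made for them only; others in the source may bear on it.

In a functional assay with Oryctolagus cuniculus as the target (a lower number here means a stronger inhibitor, a higher number a weaker inhibitor), compound 1 `C/N=C(/NC)Nc1nc(-c2ccc(OC)cc2)c(-c2ccc(OC)cc2)s1` gives 970 nM and compound 2 `COc1ccc(-c2nc(CN(C)C)sc2-c2ccc(OC)cc2)cc1` gives 96 nM, the lower of the two numbers, with a 10-fold lower number from compound 1 to compound 2 (1.00 log units; beyond the scatter). Compound 3 `COc1ccc(-c2nc(CNC(=O)CSC)sc2-c2ccc(OC)cc2)cc1` differs from compound 2 by (((methylsulfanyl)methyl)carbonyl)amino in place of dimethylamino on a saturated chain carbon bound to an aromatic carbon, with the new group on a saturated chain carbon bound to an aromatic carbon. Among the compounds with values here, the only measured step, a 10-fold lower number from compound 1 to compound 2 (1.00 log units; beyond the scatter), was made on an aromatic carbon, so it shows only that such changes can exceed the scatter and gives no firm direction. A modest rise is expected, estimated as a 3.1-fold higher number from compound 2 to compound 3 (0.49 log units; beyond the scatter). Compound 3 is estimated at 300 nM, within an expected range of 60 nM to 1500 nM.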

Compound 3, half-maximal inhibitory concentration: < 100 nM
Compound 3: only a limit was reported; the forecaster's own chance of this, stated with the estimate: 5%; middle value at least 3.0-fold (0.47 log units) away from the limit.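

In this assay compound 3 is reported only as a limit, < 100 nM. On a saturated chain carbon bound to an aromatic carbon, the larger (((methylsulfanyl)methyl)carbonyl)amino group, which brings a hydrogen-bond donor that dimethylamino lacks, is therefore tolerated, with an at least 9.7-fold lower number from compound 1 to compound 3 (0.98 log units; beyond the scatter). From the compounds shown here alone, the step from compound 2 to compound 3 cannot be read, so it remains unknown whether this change raises or lowers the number. Also open, going by these compounds, is whether the sulfur matters: a plain acetylamino group or a carboxylic acid at this place would be informative.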